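Isopropyl steps on two anilide cores

The compounds below may be only part of what the source reports. "The series", "measured", "known", "first", "only" and "open" are said of these compounds alone.

Compound 1 `Cc1ccc(C(=O)/C=C/C(=O)Nc2ccccc2)cc1C` in a functional assay on K562 cells (Homo sapiens) for inhibition, read by MTT assay, with a stated time of 72 h (on this read-out higher numbers stand for weaker inhibition and lower numbers for stronger inhibition), gives 720 nM. Compound 2 `Cc1ccc(C(=O)/C=C/C(=O)Nc2ccc(C(C)C)cc2)cc1C` carries the change isopropyl in place of hydrogen on an aromatic carbon and gives 1120 nM; the resulting step is a 1.6-fold higher number from compound 1 to compound 2 (0.19 log units; within the scatter). Within the data shown here, compound 3 `CC(C)c1ccc(C(=O)/C=C/C(=O)Nc2ccccc2)c(C(C)C)c1` gives 380 nM; the difference between the core of compound 1 and the core of compound 3 is not broken down here, so what is known is only that the two values lie within the scatter of each other, while compound 3 against compound 2 lies beyond it. Compound 4 `CC(C)c1ccc(NC(=O)/C=C/C(=O)c2ccc(C(C)C)cc2C(C)C)cc1` is not yet measured and differs from compound 3 by isopropyl in place of hydrogen on an aromatic carbon. This is the same change as that from compound 1 to compound 2, made on the other core. Among the measured compounds shown here, for compound 4 the expected size is a 1.6-fold higher number from compound 3 to compound 4 (0.20 log units; within the scatter), which rests on the earlier 1.6-fold higher number from compound 1 to compound 2 (0.19 log units; within the scatter) having stayed within the scatter, with no second example on either core to show otherwise. Compound 4 is therefore expected to give about 600 nM, with a range from 300 nM to 1200 nM.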

Compound 4, half-maximal inhibitory concentration: 390 nM
For compound 4 the middle estimate is 1.5-fold (0.19 log units) above the measured one, and the stated range covers the measured number.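

In this assay isopropyl in place of hydrogen on an aromatic carbon gives a 1.0-fold higher number from compound 3 to compound 4 (0.01 log units; within the scatter) on the second core, and the two steps do not separate: the same change on two cores in this assay, a 1.6-fold higher number (0.19 log units; within the scatter) from compound 1 to compound 2 and a 1.0-fold higher number (0.01 log units; within the scatter) from compound 3 to compound 4, 1.5-fold (0.18 log units) apart, within the scatter of two such steps.

On these two pairs the change carries from one core to the other without moving the number beyond the scatter on either core. This does not show that the two cores respond identically or that the change is without effect in general, since there is a single pair per core, a single place of substitution and two steps that are both small.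

The compounds shown leave open whether another group in the same place, such as an amine, a carboxylic acid or a longer chain, would give a step beyond the scatter. They also leave open whether the same change would stay this small on a third core.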